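The source may report more compounds than this note shows. Statements on the series, on what has been measured and on what is new or still open speak of the compounds shown alone.

Working notes on the series. The shared core is a trimethoxybenzoyl-substituted anilide of a cinnamic acid. Compound 1 `COc1ccc(/C=C/C(=O)Nc2cc(C(=O)c3cc(OC)c(OC)c(OC)c3)ccc2OC)cc1` gives 11100 nM in a functional assay on PC-3 cells (Homo sapiens) for cytotoxicity, read by MTT assay, with a stated time of 72 h; a lower number here means a stronger inhibitor, a higher number a weaker inhibitor. Compound 2 `COc1ccc(C(=O)c2cc(OC)c(OC)c(OC)c2)cc1NC(=O)/C=C/c1cccc(OC(F)(F)F)c1` gives 7700 nM, and the change a 1.4-fold lower number from compound 1 to compound 2 (0.16 log units; within the scatter) stays within the scatter. Compound 3 `COc1ccc(/C=C/C(=O)Nc2cc(C(=O)c3cc(OC)c(OC)c(OC)c3)cc(OC)c2OC)cc1` gives 6300 nM; the step of a 1.8-fold lower number from compound 1 to compound 3 (0.25 log units; within the scatter) is also within the scatter. Compound 3 thus gives the lowest of the three numbers, but the gaps to compound 2 and compound 1 are both within the scatter, so no ordering is claimed.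

Compound 4 `COc1cc(C(=O)c2cc(OC)c(OC)c(OC)c2)cc(NC(=O)/C=C/c2ccc(C(F)(F)F)cc2)c1OC` differs from compound 3 by trifluoromethyl in place of methoxy on an aromatic carbon. Among the measured compounds shown here, no measured step exchanges methoxy for trifluoromethyl directly; the nearest comparison is the exchange of 4-methoxyphenyl for 3-(trifluoromethoxy)phenyl from compound 1 to compound 2, which stayed within the scatter. A step of similar size, that is none beyond the scatter, is therefore expected in this assay for compound 4, namely a 1.1-fold lower number from compound 3 to compound 4 (0.02 log units; within the scatter). On that basis compound 4 is estimated at 6000 nM, with a range from 2500 nM to 15000 nM.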

Compound 4, half-maximal inhibitory concentration: 4200 nM
The estimate for compound 4 lay 1.4-fold (0.15 log units) above the measured number; the range from low to high includes it.
By their numbers in this assay, from the lowest: compounds 4, 3, 2 and 1 (each within the scatter of the next, the first and the last beyond it).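

Trifluoromethyl in place of methoxy, para to a large group, gives a 1.5-fold lower number from compound 3 to compound 4 (0.18 log units; within the scatter) in this assay. Among the compounds shown here, this is the first reading of a change at this place alone: the step from compound 1 to compound 2 replaced 4-methoxyphenyl with 3-(trifluoromethoxy)phenyl, so it did not keep the substituent at this place. Here, losing the methoxy with its hydrogen-bond acceptor and introducing a group with more heavy atoms and no hydrogen-bond acceptor leaves the number within the scatter, and no measurement available here explains this result.

Open, from the compounds shown here alone, is whether an amine or a carboxylic acid at this place would also stay within the scatter of compound 3. Also open, going by these compounds, is whether a longer alkoxy chain, such as butoxy, would do the same.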